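The compounds below may be only part of what the source reports. "The series", "measured", "known", "first", "only" and "open" are said of these compounds alone.

Compound 2 `COC(=O)c1c(-c2cc3ccccc3oc2=O)nn(-c2cccc(Cl)c2)c1C(=O)OC` sits at one end of the two numbers in hand: in a functional assay on A549 cells (Homo sapiens) for cytotoxicity, read by MTT assay, with a stated time of 48 h (on this read-out lower numbers stand for stronger inhibition and higher numbers for weaker inhibition), compound 2 gives 30000 nM, while compound 1 `COC(=O)c1c(-c2cc3ccccc3oc2=O)nn(-c2cccc(C)c2)c1C(=O)OC` gives 51000 nM, and the step of a 1.7-fold lower number from compound 1 to compound 2 (0.23 log units; within the scatter) is within the scatter. Compound 3 `COC(=O)c1c(-c2cc3ccccc3oc2=O)nn(-c2ccc(Br)cc2)c1C(=O)OC` differs from compound 2 by 4-bromophenyl in place of 3-chlorophenyl on an aromatic nitrogen. Within the data shown here, the only measured step, a 1.7-fold lower number from compound 1 to compound 2 (0.23 log units; within the scatter), swaps one ring substituent for another and stays within the scatter, so no shift beyond the scatter is expected here in either direction. Compound 3 is therefore estimated at 30000 nM, between 10000 nM and 90000 nM, a step of no change at the digits printed from compound 2 to compound 3 (within the scatter).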

Compound 3, half-maximal inhibitory concentration: 165000 nM
Beside the measured number, compound 3's estimate is 5.5-fold (0.74 log units) below it, outside the stated range (above it).
By their numbers in this assay, from the lowest: compounds 2 and 1 (each within the scatter of the next); then compound 3.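

On the aromatic nitrogen of the five-membered ring, the choice of substituted phenyl does register in this assay: 4-bromophenyl brings a 5.5-fold higher number from compound 2 to compound 3 (0.74 log units; beyond the scatter), and against 3-methylphenyl it brings a 3.2-fold higher number from compound 1 to compound 3 (0.51 log units; beyond the scatter). This position therefore tolerates some swaps within the scatter but not all of them. Nothing measured here accounts for the shift.

Since both the substituent and its place on the phenyl ring change together, their shares remain unseparated. From the compounds shown here alone, how 4-chlorophenyl, 3-bromophenyl, or a phenyl ring carrying an amine or a carboxylic acid would behave here remains open.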